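The source may report more compounds than this note shows. Statements on the series, on what has been measured and on what is new or still open speak of the compounds shown alone.

Compound 3 `Cc1noc(NS(=O)(=O)c2ccc(NCC(=O)O)cc2)c1C` sits in the middle of three neighbours. In an assay on VSM-A10 cells for antagonist activity at Endothelin-1 receptor (Rattus norvegicus) (on this read-out lower numbers stand for stronger inhibition and higher numbers for weaker inhibition), compound 3 gives 12000 nM, the second highest of the three numbers. Compound 1 `CCCNc1ccc(S(=O)(=O)Nc2onc(C)c2C)cc1` gives 27000 nM in this assay, and compound 2 `Cc1noc(NS(=O)(=O)c2ccc(N/C(S)=N/c3ccccc3)cc2)c1C` gives 4100 nM. The steps among them are all modest: a 2.3-fold lower number from compound 1 to compound 3 (0.35 log units; beyond the scatter), a 2.9-fold higher number from compound 2 to compound 3 (0.47 log units; beyond the scatter) and a 6.6-fold lower number from compound 1 to compound 2 (0.82 log units; beyond the scatter). All three share the same core, and differ only in what hangs from the nitrogen on the aromatic ring.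

Compound 4 `Cc1noc(NS(=O)(=O)c2ccc(NC(=O)CN)cc2)c1C` keeps that pattern and changes the same position once more: (aminomethyl)carbonyl in place of carboxymethyl on a nitrogen on an aromatic ring. The chain keeps its length but exchanges an acid for an amide carrying a free amine. Among the measured compounds shown here, only the step from compound 1 to compound 3 touches a related exchange, a carboxy in place of ethyl, and it moved the number only modestly. For the measured compounds named here, no measured step shows an amide at this position, so the expectation leans on that modest scale alone. Compound 4 is therefore expected to land near compound 3, with a step of about a 1.3-fold higher number from compound 3 to compound 4 (0.10 log units; within the scatter), and this assay is estimated to give compound 4 a value around 15000 nM, between 6000 nM and 40000 nM.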

Compound 4, half-maximal inhibitory concentration: 6500 nM
For compound 4 the middle estimate is 2.3-fold (0.36 log units) above the measured one; measured number inside the range.
By their numbers in this assay, from the lowest: compounds 2, 4 and 3 (each within the scatter of the next, the first and the last beyond it); then compound 1.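

In this assay, (aminomethyl)carbonyl in place of carboxymethyl on a nitrogen on an aromatic ring gives a 1.8-fold lower number from compound 3 to compound 4 (0.27 log units; within the scatter), so at this position, exchanging the acid chain for an amide carrying a free amine leaves no difference that can be told from measurement scatter. The much larger group of compound 2, which carries a six-membered aromatic ring, also cannot be told apart from the small, ring-free (aminomethyl)carbonyl, with a 1.6-fold higher number from compound 2 to compound 4 (0.20 log units; within the scatter), so among these compounds that aromatic ring is not needed to reach a number in this range. Among the compounds shown here, only the exchange of propyl for (aminomethyl)carbonyl gives a step beyond the scatter, a 4.2-fold lower number from compound 1 to compound 4 (0.62 log units; beyond the scatter), and this adds to the earlier steps in leaving compound 1 with the highest number of the set.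

The compounds shown do not separate the part played by the amide carbonyl from that of the free amine, a question that a plain acetyl group or a longer chain ending in an amine would address. Nothing available here explains why these groups give the numbers they do.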